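The source may report more compounds than this note shows. Statements on the series, on what has been measured and on what is new or still open speak of the compounds shown alone.

The shared core appears in compound 1 `Oc1ccc(/C=C2\CCN=C2c2cccnc2)c(O)c1` and in compound 2 `Oc1ccc(/C=C2\CCN=C2c2cccnc2)cc1`, which differ only in their hydroxy substitution on the six-membered aromatic ring. In an assay for displacement of a labelled ligand from Nicotinic acetylcholine receptor alpha8 subunit (Periplaneta americana), read by scintillation counting, with a stated time of 2 h, at 24 degrees C (a higher number here means a weaker inhibitor, a lower number a stronger inhibitor), compound 1 gives 120 nM, and compound 2 gives 310 nM. The step of a 2.6-fold higher number from compound 1 to compound 2 (0.41 log units; beyond the scatter) shows that taking away a hydroxy weakens binding. Compound 3 `COc1ccccc1/C=C1\CCN=C1c1cccnc1` carries a methoxy in place of hydroxy. In this assay compound 3 reaches only a limit, > 10000 nM, so no number is available for it. That limit, (the limit of > 10000 nM in this assay, at which 1 of the 3 values shown sits), is the ceiling of the measurement. Among the two numbers available, compound 2 stands as the higher one, its nearest neighbour being compound 1 at a lower number.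

Compound 4 `N#Cc1ccc(/C=C2\CCN=C2c2cccnc2)cc1` has not yet been measured. It differs from compound 2 by cyano in place of hydroxy on an aromatic carbon. Within the data shown here, the one measured step that bears on this change is a 2.6-fold higher number from compound 1 to compound 2 (0.41 log units; beyond the scatter), a modest loss when a hydroxy disappears. Compound 3, which also lacks a hydroxy, reached only a limit. Compound 4 is therefore expected to bind more weakly than its parent, with an expected step of a 9.7-fold higher number from compound 2 to compound 4 (0.99 log units; beyond the scatter), and a real chance that only a limit is reported. The estimate for compound 4 in this assay is 3000 nM, between 700 nM and 12000 nM.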

Compound 4, half-maximal inhibitory concentration: > 10000 nM
Compound 4: no number, only a limit; the forecaster's own chance of this, stated with the estimate: 30%; at least 3.3-fold (0.52 log units) between middle value and limit.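

In this assay, among these compounds, putting cyano in place of the hydroxy para to a large group gives a large step, an at least 32-fold higher number from compound 2 to compound 4 (1.50 log units; beyond the scatter), whereas the only earlier step on this ring, with a different hydroxy removed, was modest: a 2.6-fold higher number from compound 1 to compound 2 (0.41 log units; beyond the scatter). Compound 4 gives only a limit, > 10000 nM, not a number. Cyano keeps a hydrogen-bond acceptor on this carbon but brings no hydrogen-bond donor, so at this position keeping an acceptor alone is not enough to retain binding, and compound 2 shows that the hydroxy here goes with a measurable number.

Going by these compounds, this single swap cannot separate the loss of the donor from the arrival of the larger cyano group, and how an amine or a carboxylic acid on the same carbon would behave remains open. Nothing ranks the compounds that stop at the ceiling against one another: the limit of > 10000 nM in this assay, at which 2 of the 4 values shown sit.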